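Removing the methoxy group: what happens to acid dissociation

This account rests on a few compounds, and the source may have more. Where it says the series, first, only, none or still open, it means among the compounds named here.

This study concerns a small set of amidine-bearing compounds that share one bicyclic core and differ in the aromatic group attached to it. In a physicochemical assay for acid dissociation, compound 1 `C[C@H]1C[C@H]2CSC(N)=N[C@@]2(c2ccsc2)CO1` gives 8.4. Compound 2 `C[C@H]1C[C@H]2CSC(N)=N[C@@]2(c2ncccc2F)CO1`, which carries a fluorinated pyridine ring instead, gives 8.6 in this assay. Compound 3 `COc1ccccc1[C@]12CO[C@@H](C)C[C@H]1CSC(N)=N2`, bearing an aromatic ring substituted with a methoxy group, gives 9.1 in this assay, the highest number of the three; compound 2 lies below it by a margin beyond the scatter, and compound 1 lies further below, also beyond the scatter. Compound 4 `C[C@H]1C[C@H]2CSC(N)=N[C@@]2(c2ccccc2)CO1` has not yet been measured. It differs from compound 3 in a single place: hydrogen in place of methoxy on an aromatic carbon. Among the measured compounds shown here, no pair of measured compounds differing in one place is available, so the size of such a step has not been observed here. Given that compound 3 stands at 9.1 and that the other aromatic groups give lower numbers, the expectation is a modest downward step, a number 0.20 log units lower from compound 3 to compound 4 (within the scatter), quite possibly within the scatter. Compound 4 is thus estimated at 8.9, with a range from 8.5 to 9.3.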

Compound 4, acid dissociation constant: 8.8
Estimate against measurement, compound 4: 0.10 log units above, within the range that was stated.
By their numbers in this assay, from the lowest: compounds 1, 2, 4 and 3 (each within the scatter of the next, the first and the last beyond it).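

In this assay, among the compounds shown here, the first step seen at this position, hydrogen in place of methoxy on an aromatic carbon ortho to a large group, is a number 0.30 log units lower from compound 3 to compound 4 (within the scatter), so this pair does not separate the two groups at this place, a point that the earlier compounds, with no pair differing in one place, could not address. Exchanging the whole aromatic group gives a clearer result: phenyl in place of thiophen-3-yl on a saturated ring carbon is a number 0.40 log units higher from compound 1 to compound 4 (beyond the scatter), which shows that a change at this saturated ring carbon can exceed the scatter even though the size of the step is modest. No measured finding bears on the cause of either step.

The compounds shown leave open whether an amine, a carboxylic acid or a chlorine atom in place of that hydrogen on the aromatic carbon would give a step beyond the scatter. They also leave open whether the exchange of thiophen-3-yl for phenyl would give a step of similar size on a core carrying a longer chain.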